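The source may hold more compounds than are shown below. What is called first, only, known or untested is meant among the compounds shown, and "the series" means these compounds.

Measured so far:
Compound 1, `Cc1cc(S(N)(=O)=O)ccc1NC(=O)COc1ccc2cc(Br)ccc2c1C(=O)c1cccc(F)c1`, in an ADME assay on C8166 cells (Homo sapiens) for cytotoxicity, read by colorimetric assay and MTT assay (a higher number here means that more compound is tolerated, a lower number that less compound is tolerated), gives 31000 nM.
Compound 2, `Cc1ccc(C)c(C(=O)c2c(OCC(=O)Nc3ccc(S(N)(=O)=O)cc3C)ccc3cc(Br)ccc23)c1`, in this assay gives 14000 nM.

For the measured compounds named here, of the two numbers known, compound 2 stands at the lower end, and its only neighbour is compound 1, which tolerates more compound; the step of a 2.2-fold lower number from compound 1 to compound 2 (0.35 log units; beyond the scatter) is modest but lies beyond the scatter. Going by the values given here, the only structural change measured so far therefore swaps one aryl group on the carbonyl carbon for another and moves the readout by a small amount.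

Compound 3, `Cc1cc(S(N)(=O)=O)ccc1NC(=O)COc1ccc2cc(Br)ccc2c1C(=O)c1cc(Cl)cc(Br)c1`, has not yet been measured in this assay. It differs from compound 2 by 3-bromo-5-chlorophenyl in place of 2,5-dimethylphenyl on a carbonyl carbon. The change again touches only the aryl group on the carbonyl carbon, the same position altered from compound 1 to compound 2. That step is the only one that bears on the present one, and it was modest. The incoming group carries halogens, as the group of compound 1 does, while the outgoing group carries the two methyls of compound 2. A step of about the same modest size is expected, most likely back toward the value of compound 1, so that compound 3 is expected to show a 1.4-fold higher number from compound 2 to compound 3 (0.15 log units; within the scatter). The estimate for compound 3 in this assay is 20000 nM, with a range from 9000 nM to 45000 nM.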

Compound 3, half-maximal cytotoxic concentration: 28500 nM
The estimate for compound 3 lay 1.4-fold (0.15 log units) below the measured number; the measured number falls inside the stated range.
By their numbers in this assay, from the lowest: compound 2; then compounds 3 and 1 (each within the scatter of the next).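

In this assay, putting 3-bromo-5-chlorophenyl in place of 2,5-dimethylphenyl on the carbonyl carbon gives a 2.0-fold higher number from compound 2 to compound 3 (0.31 log units; beyond the scatter), so this position responded a second time, now to a different incoming group. The new compound also shows that two differently halogenated aryl groups can give matching results, since the change from 3-fluorophenyl to 3-bromo-5-chlorophenyl gives a 1.1-fold lower number from compound 1 to compound 3 (0.04 log units; within the scatter), and the two compounds cannot be told apart in this measurement. Across these three compounds only, the two halogen-bearing groups sit together and the dimethyl-bearing compound 2 tolerates the least compound, but no measurement here offers an explanation for that split.

The compounds shown leave open whether the two methyl groups lower the number or the halogens raise it, as a plain unsubstituted phenyl group would be needed as a reference point for that question. From the compounds shown here alone, it also remains open how this position would respond to a group of a different kind, such as an amine or a carboxylic acid on the aryl ring.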